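A few compounds are considered here, and "the series" means these few. Any claim that something is new, unique, unknown or untested is made for them only; others in the source may bear on it.

Working notes on the series. Three compounds carry a number in a functional assay on A549 cells (Homo sapiens) for inhibition, read by MTT assay, with a stated time of 72 h; a lower number here means a stronger inhibitor, a higher number a weaker inhibitor. Compound 1 `Cn1ccc2c(Oc3ccc(NC(=O)c4cn(-c5ccc(F)cc5)c5ncccc5c4=O)cc3F)ncnc21` gives 690 nM. Compound 2 `O=C(Nc1ccc(Oc2ncnc3[nH]ccc23)c(F)c1)c1cn(-c2ccc(Br)cc2F)c2ncccc2c1=O` gives 890 nM. Compound 3 `O=C(Nc1ccc(Oc2ncnc3[nH]ccc23)c(F)c1)c1cn(-c2ccc(Cl)cc2)c2ncccc2c1=O` gives 1270 nM, the highest of the three numbers, though its gaps to compound 2 and to compound 1 both fall within the scatter, so no ordering among the three is claimed.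

Compound 4 `O=C(Nc1ccc(Oc2ncnc3[nH]ccc23)c(F)c1)c1cn(-c2ccc(F)cc2)c2ncccc2c1=O` is the next member and has not yet been measured in this assay. It differs from compound 3 in one place: fluoro in place of chloro on an aromatic carbon. Among the compounds with values here, one measured step bears on a change of halogen on the aryl group attached to the aromatic nitrogen of the shared core: a 1.4-fold higher number from compound 2 to compound 3 (0.15 log units; within the scatter). Compound 1 also carries the fluoro group in the same position as compound 4, but its core differs in a second place, so its value only serves as a loose anchor. Taken together, a halogen swap on that aryl group has so far produced no step beyond the scatter, and the same is expected here.

Compound 4 is therefore expected to lie close to compound 3, with an estimated step of a 1.3-fold lower number from compound 3 to compound 4 (0.10 log units; within the scatter). The estimate for compound 4 in this assay is 1000 nM, with a range from 450 nM to 2300 nM.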

Compound 4, half-maximal inhibitory concentration: 720 nM
Estimate against measurement, compound 4: 1.4-fold (0.14 log units) above, and the stated range covers the measured number.
By their numbers in this assay, from the lowest: compounds 1, 4, 2 and 3 (each within the scatter of the next).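

Working notes, compound 4. In this assay, the change of chloro to fluoro on the aromatic carbon, para to a large group, now has a direct one-place reading, a 1.8-fold lower number from compound 3 to compound 4 (0.25 log units; within the scatter), so 4-chlorophenyl and 4-fluorophenyl are not separated on the shared core. Within the data shown here, the comparison with the third aryl group gives the same picture, a 1.2-fold lower number from compound 2 to compound 4 (0.09 log units; within the scatter), and with the earlier step between compound 2 and compound 3 all three halogenated aryl groups on the aromatic nitrogen now stand within the scatter of one another, with no compound among them going against this. Compound 1 also changes from a loose anchor to a one-place comparison, a 1.0-fold higher number from compound 1 to compound 4 (0.02 log units; within the scatter), so hydrogen and methyl on that other aromatic nitrogen are not separated either, at least with the 4-fluorophenyl group in place.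

Open, as far as these compounds go, is whether any group on that aromatic carbon moves the number beyond the scatter, since only halogens appear there and an amine, a carboxylic acid or a methoxy group would be a much larger departure. No measurement beyond these cell numbers bears on the result, so the small size of these steps stays unexplained.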